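Chloro to hydrogen on the core of compound 1

The source may report more compounds than this note shows. Statements on the series, on what has been measured and on what is new or still open speak of the compounds shown alone.

Measured so far:
compound 1 `ClCc1cccc(Cn2cnc3c(Cl)nc(Cl)nc32)c1`: 8910 nM
compound 2 `Nc1nc(Cl)c2ncn(Cc3ccc(CCl)cc3)c2n1`: 97700 nM

Two compounds have numbers in a functional assay on TK-10 cells (Homo sapiens) for cytotoxicity, read by sulforhodamine B assay, with a stated time of 48 h; a higher number here means that more compound is tolerated, a lower number that less compound is tolerated. Compound 1 stands at the lowest of the two, that is, it is the one of which least is tolerated; compound 2 has the higher number, and the gap between the two lies beyond the usual scatter. Going by the values given here, no step between measured compounds that differ in one place is available, so nothing of the size of a single change is known from these two alone.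

Compound 3 `ClCc1cccc(Cn2cnc3c(Cl)ncnc32)c1` is not yet measured. It differs from compound 1 by hydrogen in place of chloro on an aromatic carbon, the aromatic carbon in question lying between two ring nitrogen atoms of the shared core. A change at a carbon of the core also sets compound 1 apart from compound 2, and compound 2 gives 97700 nM, a higher number. The expectation is therefore a step upward, beyond the scatter, estimated as a 2.5-fold higher number from compound 1 to compound 3 (0.39 log units; beyond the scatter). For compound 3 the estimate in this assay is 22000 nM, expected to fall between 7000 nM and 65000 nM.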

Compound 3, concentration lethal to 50% of the cells: 46800 nM
Compound 3: middle estimate off by 2.1-fold (0.33 log units), on the low side, within the range that was stated.
By their numbers in this assay, from the lowest: compound 1; then compound 3; then compound 2.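

In this assay, going by these compounds alone, hydrogen in place of chloro on the aromatic carbon between two ring nitrogen atoms gives a 5.3-fold higher number from compound 1 to compound 3 (0.72 log units; beyond the scatter), the first step that can be read for a change in one place. It shows that this carbon of the shared core matters on its own: more compound is tolerated with hydrogen here than with chloro, and the difference lies beyond the scatter, while the other chloro group on the core and the rest of the structure stay the same. Nothing at hand gives a reason for the step.

On these data alone, at this carbon, the pair compares only chloro and hydrogen, so it remains open where a methyl or methoxy group would fall relative to these two. Also open, as far as these compounds go, is whether the same exchange gives a step of similar size and direction when the chloromethyl group stands elsewhere on the benzyl ring, as it does in compound 2, or whether this step belongs only to the arrangement shared by compound 1 and compound 3.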